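A few compounds are considered here, and "the series" means these few. Any claim that something is new, unique, unknown or untested is made for them only; others in the source may bear on it.

Of the compounds shown here, three built on a shared core have been measured in an assay on PMNL cells for inhibition of Polyunsaturated fatty acid 5-lipoxygenase (Homo sapiens), read by HPLC, with stated times of 15 min and 10 min; on this read-out lower numbers stand for stronger inhibition and higher numbers for weaker inhibition. Compound 1 `COc1ccc(C2=NC(=O)/C(=C/c3cc4ccccc4[nH]3)S2)cc1` gives 570 nM. Compound 2 `COc1ccc(/C=C2\SC(c3ccc(Oc4ccccc4)cc3)=NC2=O)c2ccccc12` gives 140 nM, the second highest of the three numbers. Compound 3 `O=C1N=C(c2ccc(Cl)cc2)S/C1=C\c1ccc(Oc2ccccc2)cc1` gives 80 nM; the gap between compound 2 and compound 3 lies within the scatter, while the gap between compound 2 and compound 1 lies beyond it. Compound 4 `COc1ccc(/C=C2\SC(c3ccc(Cl)cc3)=NC2=O)c2ccccc12` has not been measured; it differs from compound 2 by chloro in place of phenoxy on an aromatic carbon. Going by the values given here, no measured pair shows this single change on its own, so no step size can be read off. The step from compound 2 to compound 4 is expected to be a 1.2-fold lower number from compound 2 to compound 4 (0.07 log units; within the scatter), nothing beyond the scatter. Compound 4 is expected to give about 120 nM in this assay, within a range of 45 nM to 320 nM.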

Compound 4, half-maximal inhibitory concentration: 130 nM
The estimate for compound 4 lay 1.1-fold (0.03 log units) below the measured number; the range from low to high includes it.
By their numbers in this assay, from the lowest: compounds 3, 4 and 2 (each within the scatter of the next); then compound 1.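

Swapping phenoxy for chloro on this aromatic carbon gives a 1.1-fold lower number from compound 2 to compound 4 (0.03 log units; within the scatter). Going by these compounds alone, this is the first direct reading of the change, and it shows that a single chlorine can take the place of a group carrying a whole aromatic ring with no difference that stands clear of the scatter. No measurement here speaks to why the two groups read alike.

Still open, as far as these compounds go, is how other groups at this place, such as an amine, a carboxylic acid or a longer chain, would read. From the compounds shown here alone, whether the same swap would read alike on a different group elsewhere on the shared core also remains unknown.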